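The compounds below may be only part of what the source reports. "The series", "measured", "known", "first", "only" and "open" are said of these compounds alone.

Measured compounds:
compound 1, `CCCCC1CC(=O)N(c2ccccc2C(=O)OCC2CCCN(CCCc3ccccc3)C2)C1=O`, 1500 nM
compound 2, `CCCCCCCCC1CC(=O)N(c2ccccc2C(=O)OCC2CCCN(CCCc3ccccc3)C2)C1=O`, 1300 nM
compound 3, `O=C(OCC1CCCN(CCCc2ccccc2)C1)c1ccccc1N1C(=O)CC(C2CCCC2)C1=O`, 1200 nM

All three were characterised in a functional assay with Neuronal acetylcholine receptor; alpha3/beta4 (Homo sapiens) as the target; on this read-out lower numbers stand for stronger inhibition and higher numbers for weaker inhibition. Compound 3 gives the smallest of the three numbers, yet every gap to its neighbours lies within the scatter: the step of a 1.1-fold lower number from compound 2 to compound 3 (0.03 log units; within the scatter) and the step of a 1.3-fold lower number from compound 1 to compound 3 (0.10 log units; within the scatter) are both too small to count as real differences. Compound 4, `C=CCC1CC(=O)N(c2ccccc2C(=O)OCC2CCCN(CCCc3ccccc3)C2)C1=O`, has not yet been measured in this assay. It differs from compound 3 by allyl in place of cyclopentyl on a saturated ring carbon.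

Among the compounds with values here, three measured steps bear on this position. Extending the chain, a 1.2-fold lower number from compound 1 to compound 2 (0.06 log units; within the scatter), changed nothing beyond the scatter. Exchanging butyl for cyclopentyl, a 1.3-fold lower number from compound 1 to compound 3 (0.10 log units; within the scatter), and exchanging octyl for cyclopentyl, a 1.1-fold lower number from compound 2 to compound 3 (0.03 log units; within the scatter), likewise left the read-out essentially unchanged. Butyl, octyl and cyclopentyl at this saturated ring carbon thus all give indistinguishable numbers, and allyl, a short chain at the same place, is expected to behave in the same way. No step beyond the scatter is therefore expected in this assay; the expected step is a 1.2-fold higher number from compound 3 to compound 4 (0.07 log units; within the scatter). Compound 4 is estimated to give 1400 nM, with a range from 700 nM to 2800 nM.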

Compound 4, half-maximal inhibitory concentration: 1700 nM
Estimate against measurement, compound 4: 1.2-fold (0.08 log units) below; the measured number falls inside the stated range.
By their numbers in this assay, from the lowest: compounds 3, 2, 1 and 4 (each within the scatter of the next).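

In this assay the position also tolerates a group of a different kind: allyl replaces cyclopentyl (a 1.4-fold higher number from compound 3 to compound 4 (0.15 log units; within the scatter)), so the five-membered ring goes, the group shrinks from 5 heavy atoms to 3, and a double bond outside aromatic rings comes in, yet the change stays within the scatter. The comparisons with the saturated chains agree (a 1.3-fold higher number from compound 2 to compound 4 (0.12 log units; within the scatter)) and (a 1.1-fold higher number from compound 1 to compound 4 (0.05 log units; within the scatter)), so the four carbon-only groups on this saturated ring carbon cannot be told apart, and neither ring, chain length nor the double bond has a resolved effect here. No measurement available explains why the read-out stays so flat at this position.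

As far as these compounds go, all four groups have 0 hydrogen-bond donors, 0 hydrogen-bond acceptors and no net charge, so it remains open whether an amine, a carboxylic acid or a hydroxyl group on this carbon would give a step beyond the scatter. From the compounds shown here alone, it also remains open whether a phenyl ring there, or plain hydrogen in place of the group, would do so, and whether changes elsewhere on the shared core would matter more than this position does.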